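The compounds below may be only part of what the source reports. "The series", "measured", "known", "first", "only" and "open" are said of these compounds alone.

In a functional assay on ASK cells (Rattus norvegicus) for cytotoxicity, read by sulforhodamine B assay (a higher number here means that more compound is needed for the effect, a lower number that less compound is needed), compound 1 (`C=C1CC[C@@H]2[C@](C)(COC(C)=O)[C@H](OC(C)=O)CC[C@@]2(C)[C@@H]1C/C=C1/C(=O)OC[C@H]1OC(C)=O`) gives 11.4 uM and compound 2 (`C=C1CC[C@@H]2[C@](C)(CO[Si](c3ccccc3)(c3ccccc3)C(C)(C)C)[C@H](OC(C)=O)CC[C@@]2(C)[C@@H]1C/C=C1/C(=O)OC[C@H]1O`) gives 10.5 uM and these two values lie within the scatter of each other, so neither stands apart. Compound 3 (`C=C1CC[C@@H]2[C@](C)(CO[Si](C(C)C)(C(C)C)C(C)C)[C@H](OC(C)=O)CC[C@@]2(C)[C@@H]1C/C=C1/C(=O)OC[C@H]1OC(C)=O`) keeps the core of compound 1 and differs in one place, on an oxygen on a saturated carbon, where the change is a group of 10 heavy atoms (9 carbon, 1 silicon; no ring) in place of a group of 3 heavy atoms (2 carbon, 1 oxygen; no ring), on an oxygen on a saturated carbon and a larger group holding silicon replaces the acetyl. Among the measured compounds shown here, no measured pair here shows such a swap alone, so no shift in either direction is expected. The estimated move a 1.1-fold lower number from compound 1 to compound 3 (0.04 log units; within the scatter) stays within the scatter. The expected value for compound 3 is 10.5 uM (range 5 uM to 22 uM).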

Compound 3, concentration for half-maximal effect: 7.56 uM
For compound 3 the middle estimate is 1.4-fold (0.14 log units) above the measured one; the measured number falls inside the stated range.
By their numbers in this assay, from the lowest: compounds 3, 2 and 1 (each within the scatter of the next).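

Among the compounds shown here, the step of a 1.5-fold lower number from compound 1 to compound 3 (0.18 log units; within the scatter) in this assay is the first single-place swap seen here. It shows that on an oxygen on a saturated carbon, a group of 10 heavy atoms (9 carbon, 1 silicon; no ring) can replace the acetyl without moving the number beyond the scatter. No measurement shown here offers an explanation for this result. As far as these compounds go, whether a bare hydroxyl or an amine in this place would shift the number beyond the scatter stays open.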